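The compounds below may be only part of what the source reports. "The series", "measured", "known", "first", "only" and "open" are said of these compounds alone.

Measured in an ADME assay on HepG2 2.2.15 cells (Homo sapiens) for cytotoxicity, read by luminescence, with a stated time of 3 days; on this read-out higher numbers stand for lower toxicity in this test and lower numbers for higher toxicity in this test:
- compound 1 `O=C(Nc1ccc(F)c(Cl)c1)c1ccc(F)c(S(=O)(=O)N2CCOC[C@H](O)C2)c1`: 19000 nM
- compound 2 `COC1COCCN(S(=O)(=O)c2cc(C(=O)Nc3ccc(F)c(Cl)c3)ccc2F)C1`: 8700 nM

Of the two numbers, compound 2 holds the lower at 8700 nM. Compound 3 `O=C(Nc1ccc(F)c(Cl)c1)c1ccc(F)c(S(=O)(=O)N2CCCCCCC2O)c1` is still unmeasured and differs from compound 2 as follows: a group of 9 heavy atoms (7 carbon, 1 nitrogen, 1 oxygen; one eight-membered non-aromatic ring with 1 hetero atom) in place of a group of 9 heavy atoms (6 carbon, 1 nitrogen, 2 oxygen; one seven-membered non-aromatic ring with 2 hetero atoms), on a sulfonyl sulfur. Among the measured compounds shown here, one measured step bears on it, the modest 2.2-fold lower number from compound 1 to compound 2 (0.34 log units; beyond the scatter). For the measured compounds named here, that step changes only the substituent on the ring, so no measured step covers an exchange of the ring itself. A modest move upward is expected, with a 1.4-fold higher number from compound 2 to compound 3 (0.14 log units; within the scatter) as the estimated step. For compound 3 the estimated value is 12000 nM, with an expected range of 5000 nM to 30000 nM.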

Compound 3, half-maximal cytotoxic concentration: 7000 nM
For compound 3 the middle estimate is 1.7-fold (0.23 log units) above the measured one; the range from low to high includes it.
By their numbers in this assay, from the lowest: compounds 3 and 2 (each within the scatter of the next); then compound 1.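

In this assay, putting the eight-membered ring with one hetero atom on the sulfonyl sulfur in place of 6-methoxy-1,4-oxazepan-4-yl gives a 1.2-fold lower number from compound 2 to compound 3 (0.09 log units; within the scatter), so this first exchange of the ring itself leaves the read-out within the scatter. The same ring, set against the 6-hydroxy-1,4-oxazepan-4-yl group, gives a 2.7-fold lower number from compound 1 to compound 3 (0.43 log units; beyond the scatter), a step of modest size. Nothing available bears on the cause of either step. The compounds shown leave open how an amine or a carboxylic acid on this ring would read here.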